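The source may hold more compounds than are shown below. What is called first, only, known or untested is meant among the compounds shown, and "the series" means these compounds.

Measured compounds:
- compound 1 `C/C(=N\NC(=S)N1CCNCC1)c1ccc(Cl)cc1`: 260 nM
- compound 2 `COc1ccc(/C=N/NC(=S)N2CCNCC2)cc1`: 1620 nM

In a functional assay on HBL-100 cells (Homo sapiens) for antiproliferative activity, read by MTT assay, with a stated time of 72 h (a lower number here means a stronger inhibitor, a higher number a weaker inhibitor), compound 1 gives 260 nM, the lowest of the two numbers at hand. Among the measured compounds shown here, compound 2 gives 1620 nM in this assay, a higher number that lies well beyond the scatter; these two compounds differ in more than one place, so their values show only that compound 1 is the stronger inhibitor of the pair, not what any single change does.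

Compound 3 `C/C(=N\NC(=S)N1CCNCC1)c1ccc(O)cc1` is not yet measured. It differs from compound 1 by hydroxy in place of chloro on an aromatic carbon. For the measured compounds named here, no step between measured compounds isolates this change, so its effect can only be guessed from the two values above. Going by the values given here, the only other compound carrying an oxygen substituent on that ring, compound 2, is the weaker one, but it also differs elsewhere. A modest weakening, possibly beyond the scatter, is expected from compound 1 to compound 3, as the step of a 3.1-fold higher number from compound 1 to compound 3 (0.49 log units; beyond the scatter) in this assay. Compound 3 is therefore estimated at 800 nM in this assay, within a range of 250 nM to 2500 nM.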

Compound 3, half-maximal inhibitory concentration: 540 nM
The estimate for compound 3 lay 1.5-fold (0.17 log units) above the measured number; measured number inside the range.
By their numbers in this assay, from the lowest: compound 1; then compound 3; then compound 2.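

In this assay, among the compounds shown here, hydroxy in place of chloro on an aromatic carbon, para to a large group, gives a 2.1-fold higher number from compound 1 to compound 3 (0.32 log units; beyond the scatter), the first step here that isolates a single change. The step is modest, and this place on the six-membered aromatic ring therefore accepts the exchange with only a limited loss: compound 1 carries chloro, with no hydrogen-bond donor or acceptor, while compound 3 carries hydroxy, with one of each, and compound 3 still gives 540 nM. No supporting evidence is at hand to account for the size of this step.

The compounds shown leave open how other groups would fare at this same place, such as an amine, a carboxylic acid or a fluoro substituent, so a single exchange cannot yet show a trend across substituents there. They also leave open whether a longer chain elsewhere on the shared core would shift the number in this assay, and whether the step seen here would keep its size on a core carrying such a chain.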